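A few compounds are considered here, and "the series" means these few. Any claim that something is new, unique, unknown or untested is made for them only; others in the source may bear on it.

Working notes on the series, read in a functional assay on K562 cells (Homo sapiens) for antiproliferative activity, with a stated time of 72 h; a lower number here means a stronger inhibitor, a higher number a weaker inhibitor. Compound 1 `COc1cccc(CNc2ncnc3c2ncn3[C@@H]2O[C@H](CO)[C@@H](O)[C@H]2O)c1` is reported as > 166000 nM, which is a limit and not a number. Compound 2 `COc1cc(CNc2ncnc3c2ncn3[C@@H]2O[C@H](CO)[C@@H](O)[C@H]2O)cc(OC)c1` is reported as > 166000 nM, also a limit. Compound 3 `OC[C@H]1O[C@@H](n2cnc3c(NCc4ccc(F)c(F)c4F)ncnc32)[C@H](O)[C@@H]1O` is reported as > 166000 nM, again a limit, so compound 3 has no number of its own. All measured compounds stand at the same place: the limit of > 166000 nM in this assay, at which 3 of the 3 values shown sit.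

The next compound is compound 4 `Cc1cccc(CNc2ncnc3c2ncn3[C@@H]2O[C@H](CO)[C@@H](O)[C@H]2O)c1O`, where 2-hydroxy-3-methylphenyl takes the place of 2,3,4-trifluorophenyl on a saturated chain carbon bound to a nitrogen on an aromatic ring: 2-hydroxy-3-methylphenyl in place of 2,3,4-trifluorophenyl on a saturated chain carbon bound to a nitrogen on an aromatic ring.

The measured steps that bear on this change alter the same aromatic group: a step that the two limits leave unreadable from compound 1 to compound 3, a step that the two limits leave unreadable from compound 2 to compound 3 and a step that the two limits leave unreadable from compound 1 to compound 2. For the measured compounds named here, none of them gives a size, so the series offers no measured precedent for the new group. Compound 3 sits at a limit, so any readable result could only point toward stronger inhibition, while a further limit remains about as likely. The expected outcome is an at least 1.8-fold lower number from compound 3 to compound 4 (0.26 log units; that floor lies within the scatter), an estimate that carries wide uncertainty. For compound 4 the estimated value is 90000 nM, with an expected range from 12000 nM to 166000 nM.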

Compound 4, half-maximal inhibitory concentration: 18000 nM
Compound 4: the middle estimate sits 5.0-fold (0.70 log units) above what was measured; the range from low to high includes it.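

In this assay, the aromatic group on a saturated chain carbon bound to a nitrogen on an aromatic ring now gives readable steps, while the steps among compounds 1, 2 and 3 cannot be read: the change to 2-hydroxy-3-methylphenyl gives an at least 9.2-fold lower number from compound 3 to compound 4 (0.96 log units; beyond the scatter), an at least 9.2-fold lower number from compound 2 to compound 4 (0.96 log units; beyond the scatter) and an at least 9.2-fold lower number from compound 1 to compound 4 (0.96 log units; beyond the scatter). This shows that a change at this position alone can move the read-out off the limit, and that the 2-hydroxy-3-methylphenyl group differs from the 3-methoxyphenyl, 3,5-dimethoxyphenyl and 2,3,4-trifluorophenyl groups by more than the scatter. Compound 4 is the only compound shown with a number, so the three other aromatic groups remain unranked among themselves: the limit of > 166000 nM in this assay, at which 3 of the 4 values shown sit.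

The compounds shown do not separate the contributions of the hydroxy and methyl groups of the 2-hydroxy-3-methylphenyl group, so it stays open whether either one alone would give a step of this size. Also open, going by these compounds, is whether an amine or a carboxylic acid in place of the hydroxy group of compound 4 would keep the read-out off the limit.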